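Moving the Cyclohexyl Ring One Carbon Further Out

The compounds below may be only part of what the source reports. "The series", "measured", "known", "first", "only" and "open" are said of these compounds alone.

The measured compounds and their values in a functional assay on HEK293T cells for agonist activity at histamine H2 receptor (Homo sapiens), read by beta-arrestin recruitment; on this read-out higher numbers stand for an effect only at larger amounts of compound and lower numbers for an effect already at smaller amounts:
compound 1 `Cc1nc(N)sc1CCCN/C(N)=N/C(=O)NCC(C)CCc1ccccc1`: 355 nM
compound 2 `CCCCCCNC(=O)/N=C(\N)NCCCc1sc(N)nc1C`: 85.1 nM
compound 3 `Cc1nc(N)sc1CCCN/C(N)=N/C(=O)NCC(C)C1CCCCC1`: 224 nM

All three share one core and differ only in the saturated chain that sits on the amide-type nitrogen. Among these numbers compound 3 stands second highest in this assay. Its nearest neighbour is compound 1, and the gap between them is within the scatter; its furthest is compound 2, whose number is lower by a margin beyond the scatter.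

Compound 4 `Cc1nc(N)sc1CCCN/C(N)=N/C(=O)NCC(C)CC1CCCCC1` is the unmeasured member. Compared with compound 3, the change is cyclohexylmethyl in place of cyclohexyl on a saturated chain carbon bound to two saturated chain carbons. Among the compounds with values here, two measured steps bear on this. The step of a 1.6-fold lower number from compound 1 to compound 3 (0.20 log units; within the scatter) shows that swapping one ring-bearing group for another at this same chain carbon hardly moved the number. The step of a 2.6-fold higher number from compound 2 to compound 3 (0.42 log units; beyond the scatter) shows that replacing a plain pentyl chain with a ring-bearing group raised the number modestly. Compound 4 keeps a ring-bearing group and only lengthens the link by one carbon, so the expected step of a 1.1-fold higher number from compound 3 to compound 4 (0.05 log units; within the scatter) is none beyond the scatter. Compound 4 is therefore expected to give about 250 nM in this assay, with a likely range from 110 nM to 600 nM.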

Compound 4, half-maximal effective concentration: 302 nM
Compound 4: the middle estimate sits 1.2-fold (0.08 log units) below what was measured; low and high end bracket the measured number.
By their numbers in this assay, from the lowest: compound 2; then compounds 3, 4 and 1 (each within the scatter of the next).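

In this assay, the step of a 1.3-fold higher number from compound 3 to compound 4 (0.13 log units; within the scatter) shows that this position tolerates a small change in how far out the ring sits: cyclohexylmethyl in place of cyclohexyl, on a saturated chain carbon bound to two saturated chain carbons, leaves the number within the scatter. The gap to the pentyl-bearing compound also remains, with the step of a 3.5-fold higher number from compound 2 to compound 4 (0.55 log units; beyond the scatter) lying beyond the scatter, so both cyclohexyl-bearing compounds need larger amounts than compound 2 for the same effect. Within the data shown here, the step of a 1.2-fold lower number from compound 1 to compound 4 (0.07 log units; within the scatter) adds a comparison that the earlier compounds lacked. It keeps the length of the chain and changes only the ring, and that exchange also stays within the scatter.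

Going by these compounds, whether this tolerance holds further out remains open, for example with a longer chain such as cyclohexylpropyl, or with a hydroxyl group or an amine placed on the cyclohexyl ring. Nothing measured here explains why these numbers fall as they do.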